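The compounds below may be only part of what the source reports. "The series", "measured", "known", "first", "only" and "open" are said of these compounds alone.

Compound 1 `O=C1NC(=S)S/C1=C\C1=Cc2ccccc2OC1` gives 55300 nM in a functional assay on K562 cells (Homo sapiens) for antiproliferative activity, read by MTT assay, with a stated time of 72 h; a lower number here means a stronger inhibitor, a higher number a weaker inhibitor. Compound 2 `O=C(O)CN1C(=O)/C(=C/C2=Cc3ccccc3OC2)SC1=S` carries a carboxymethyl where compound 1 has a hydrogen on the amide-type ring nitrogen. In this assay compound 2 reaches only a limit, > 100000 nM, and no number. The step of an at least 1.8-fold higher number from compound 1 to compound 2 (0.25 log units; that floor lies within the scatter) is therefore a floor rather than a measured size, and compound 2 stands at the limit of > 100000 nM in this assay, at which 1 of the 2 values shown sits. Compound 3 `COc1cccc2c1OCC(/C=C1\SC(=S)N(CC(=O)O)C1=O)=C2` differs from compound 2 in one place: methoxy in place of hydrogen on an aromatic carbon. Among the measured compounds shown here, no measured step touches the six-membered aromatic ring; the only step known, an at least 1.8-fold higher number from compound 1 to compound 2 (0.25 log units; that floor lies within the scatter), alters the ring nitrogen and ends at a limit, so it cannot be carried over to this change. With nothing to point to a shift in either direction, compound 3 is expected to sit close to where compound 2 sits, the expected step of a number no higher from compound 2 to compound 3 (the limit leaves the size open) being none beyond the scatter. Compound 3 is thus estimated at 100000 nM, within 40000 nM to 300000 nM, with a good chance that this assay again reports only a limit.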

Compound 3, half-maximal inhibitory concentration: > 200000 nM
Compound 3 gave a limit, no number; the forecaster's own chance of this, stated with the estimate: 70%; at least 2.0-fold (0.30 log units) between middle value and limit.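

In this assay, compound 2 and compound 3 both end at a limit rather than a number, so the step between them cannot be read. The compounds shown leave open whether methoxy in place of hydrogen on an aromatic carbon shifts the value at all, in which direction, and by how much.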